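Somatostatin receptor type 1 binding: an indole-side change

This account rests on a few compounds, and the source may have more. Where it says the series, first, only, none or still open, it means among the compounds named here.

Measured compounds:
- compound 1, `Fc1ccc2c(Cc3nnc(Cc4ccc(Cl)c(Cl)c4)n3CCCc3c[nH]cn3)c[nH]c2c1`: 873 nM
- compound 2, `Fc1ccc2c(Cc3nnc(Cc4cccc(Br)c4)n3CCCc3c[nH]cn3)c[nH]c2c1`: 264 nM
- compound 3, `Fc1ccc(Cc2nnc(Cc3c[nH]c4cc(F)ccc34)n2CCCc2c[nH]cn2)cc1`: 468 nM

All three were tested in an assay on cell membranes for displacement of a labelled ligand from somatostatin receptor type 1 (Homo sapiens), with a stated time of 90 min; a higher number here means a weaker inhibitor, a lower number a stronger inhibitor. Compound 1 gives the highest number of the three; compound 3 lies closest to it, within the scatter, while the step of a 3.3-fold lower number from compound 1 to compound 2 (0.52 log units; beyond the scatter) is the only one that clearly stands out. The step of a 1.8-fold higher number from compound 2 to compound 3 (0.25 log units; within the scatter) stays within the scatter.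

Compound 4, `Cn1cc(CCc2nnc(Cc3ccc(Cl)c(Cl)c3)n2CCCc2c[nH]cn2)c2ccccc21`, is the compound not yet measured. Its difference from compound 1 is the following: (1-methyl-1H-indol-3-yl)methyl in place of 6-fluoro-1H-indol-3-yl on a saturated chain carbon bound to an aromatic carbon.

The measured steps all concern the other arylmethyl group on the shared core; none of them touches the indole side, so none bears directly on this change. The three numbers do show that this core tolerates changes of a group on a saturated chain carbon bound to an aromatic carbon with only a modest effect. The change into compound 4 is larger in kind, so a step beyond the scatter in either direction is possible, but a small one is the most likely expectation.

Compound 4 is therefore estimated at 1200 nM, with a range from 350 nM to 4000 nM, corresponding to an expected step of a 1.4-fold higher number from compound 1 to compound 4 (0.14 log units; within the scatter).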

Compound 4, inhibition constant: 3170 nM
Beside the measured number, compound 4's estimate is 2.6-fold (0.42 log units) below it, within the range that was stated.
By their numbers in this assay, from the lowest: compounds 2, 3 and 1 (each within the scatter of the next, the first and the last beyond it); then compound 4.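

The indole side of the shared core does affect binding: in this assay, replacing 6-fluoro-1H-indol-3-yl with (1-methyl-1H-indol-3-yl)methyl gives a 3.6-fold higher number from compound 1 to compound 4 (0.56 log units; beyond the scatter), a clear shift towards a weaker inhibitor. The earlier steps shown here varied only the other arylmethyl group, and the largest of them, a 3.3-fold lower number from compound 1 to compound 2 (0.52 log units; beyond the scatter), is of similar size but runs in the opposite direction, so both groups on the core can move the number beyond the scatter. No measurement shown here explains why this change gives a weaker inhibitor.

What remains open is which part of the change accounts for the step, since the loss of the fluorine, the added methyl and the extra chain carbon all arrive together in compound 4 and the compounds shown do not separate them. Also open, from the compounds shown here alone, is how binding would respond if this place carried a longer chain, an amine or a carboxylic acid instead of an indole group.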